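Moving the bromine around the ring of compound 2

The source may report more compounds than this note shows. Statements on the series, on what has been measured and on what is new or still open speak of the compounds shown alone.

Measured so far:
compound 1 `O=C(COc1cccc2ccccc12)N/N=C/c1ccccc1[N+](=O)[O-]`: 3.97
compound 2 `O=C(COc1cccc2ccccc12)N/N=C/c1ccccc1Br`: 4.81
compound 3 `C/C(=N\NC(=O)COc1cccc2ccccc12)c1ccccc1`: 3.65

These three were measured in a physicochemical assay for lipophilicity, measured as octanol-water partition; on this read-out lower numbers stand for lower lipophilicity and higher numbers for higher lipophilicity. Compound 2 stands highest of the three; compound 1 is nearest, and compound 3 furthest.

The new compound 4 `O=C(COc1cccc2ccccc12)N/N=C/c1cccc(Br)c1` differs from compound 2 in one place: 3-bromophenyl in place of 2-bromophenyl on a carbon with a double bond to nitrogen. Going by the values given here, the only measured step, a number 0.84 log units higher from compound 1 to compound 2 (beyond the scatter), swaps one group for another and so says little about moving a bromine within the ring. Among the compounds with values here, with no direct precedent, the expectation is a step of a number 0.09 log units higher from compound 2 to compound 4 (within the scatter), not beyond the scatter. Compound 4 is therefore estimated at 4.9, within 4.5 to 5.3.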

Compound 4, partition coefficient: 4.81
Compound 4: middle estimate off by 0.09 log units, on the high side; the measured number falls inside the stated range.
By their numbers in this assay, from the lowest: compound 3; then compound 1; then compounds 2 and 4 (each within the scatter of the next).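

In this assay putting 3-bromophenyl in place of 2-bromophenyl gives no change at the digits printed from compound 2 to compound 4 (within the scatter) and so, at this place on the carbon with a double bond to nitrogen, this read-out does not separate the two arrangements of the same atoms. Going by these compounds alone, the earlier compounds showed only one group swapped for another, whereas this step keeps the atoms and changes how they are joined. Nothing available explains this result. From the compounds shown here alone, whether a different group, such as an amine or a carboxylic acid, would behave the same way when moved around the ring stays open.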